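The source may report more compounds than this note shows. Statements on the series, on what has been measured and on what is new or still open speak of the compounds shown alone.

Working notes on the series.

Compound 1, `N=C(NCCCc1c[nH]cn1)NCCC(c1ccccc1)c1ccccn1`, gives 1 in an assay on cardiac atrium with histamine H2 receptor (Cavia porcellus) as the target (on this read-out higher numbers stand for larger maximal responses and lower numbers for smaller maximal responses), which is the full response of the reference agonist. Compound 2, `N=C(NCCCc1c[nH]cn1)NCCC(c1ccc(Br)cc1)c1ccccn1`, gives 1 in this assay. Among the measured compounds shown here, the one step measured so far, bromo in place of hydrogen on an aromatic carbon, is no change at the digits printed from compound 1 to compound 2 (within the scatter), so a substituent on the phenyl ring has left the maximal response at the level of compound 1 and compound 2.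

Compound 3, `N=C(NCCCc1c[nH]cn1)NCCC(c1ccc(Cl)c(Cl)c1)c1ccccn1`, is not yet measured. It differs from compound 2 as follows: 3,4-dichlorophenyl in place of 4-bromophenyl on a saturated chain carbon bound to an aromatic carbon and a saturated chain carbon. For the measured compounds named here, only the step from compound 1 to compound 2 bears on it, and that step was within the scatter; the maximal response in this assay is therefore expected to stay where compound 2 stands, with no step beyond the scatter. For compound 3 the expected value in this assay is 0.95, within 0.8 to 1.05. The expected step from compound 2 to compound 3 is a number 0.050 lower from compound 2 to compound 3 (within the scatter).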

Compound 3, intrinsic activity: the largest response reached, as a fraction of the reference agonist's: 1
Beside the measured number, compound 3's estimate is 0.050 below it, within the range that was stated.
By their numbers in this assay, from the lowest: compounds 1, 2 and 3 (each within the scatter of the next).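

In this assay the place on a saturated chain carbon bound to an aromatic carbon and a saturated chain carbon shows 3,4-dichlorophenyl in place of 4-bromophenyl as no change at the digits printed from compound 2 to compound 3 (within the scatter) and 3,4-dichlorophenyl in place of phenyl as no change at the digits printed from compound 1 to compound 3 (within the scatter) on this read-out. The earlier pair covered one bromo substituent only, whereas this place now takes phenyl, 4-bromophenyl and 3,4-dichlorophenyl with the maximal response level across all of them. Nothing measured alongside these compounds offers an explanation of this level result.

As far as these compounds go, whether an amine or a carboxylic acid on the phenyl ring would leave the maximal response level remains open. So does the effect of a longer chain at this carbon.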